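The source may hold more compounds than are shown below. What is called first, only, known or untested is meant among the compounds shown, and "the series" means these compounds.

In an ADME assay on cells (Homo sapiens) for cytotoxicity, read by resazurin assay, with a stated time of 5 days (a higher number here means that more compound is tolerated, a lower number that less compound is tolerated), compound 1 `COc1ccc(-c2nc(CC(=O)c3cccc(Cl)c3)nc3ccsc23)cn1` gives 30000 nM and compound 3 `COc1ccc(-c2nc(CC(O)c3cccc(Cl)c3)nc3ccsc23)cn1` gives 31000 nM. These two values lie within the scatter of each other, so compound 3 stands level with compound 1. Compound 2 `COc1ccc(-c2nc(CCc3cccc(Cl)c3)nc3ccsc23)cn1` reads > 50000 nM, which is a limit of the assay and not a number.

Compound 4 `COc1ccc(-c2nc(CSc3cc(C)cc(C)c3)nc3ccsc23)cn1` carries (3,5-dimethylphenyl)sulfanyl in place of (3-chlorophenyl)(hydroxy)methyl on a saturated chain carbon bound to an aromatic carbon. Among the compounds with values here, no measured step makes this exact exchange. The closest evidence comes from the other changes in this part of the molecule: a 1.0-fold higher number from compound 1 to compound 3 (0.01 log units; within the scatter), an at least 1.6-fold higher number from compound 1 to compound 2 (0.22 log units; that floor lies within the scatter) and an at least 1.6-fold lower number from compound 2 to compound 3 (0.20 log units; that floor lies within the scatter). Going by these compounds, the last two are bounded by the limit of > 50000 nM in this assay, at which 1 of the 3 values shown sits, so their full size is unknown.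

None of the three steps is shown to exceed the scatter, so no step beyond it is expected here, and the estimated change is a 1.0-fold lower number from compound 3 to compound 4 (0.01 log units; within the scatter). For compound 4 the expected value in this assay is 30000 nM, within an estimated range of 12000 nM to 50000 nM.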

Compound 4, half-maximal cytotoxic concentration: > 50000 nM
Compound 4 ended at the assay's limit; the forecaster's own chance of this, stated with the estimate: 35%; middle value at least 1.6-fold (0.22 log units) away from the limit.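

In this assay compound 4 gives > 50000 nM, which is a limit of the assay and not a number. With (3,5-dimethylphenyl)sulfanyl at this place, the record shows an at least 1.6-fold higher number from compound 3 to compound 4 (0.20 log units; that floor lies within the scatter) and an at least 1.6-fold higher number from compound 1 to compound 4 (0.22 log units; that floor lies within the scatter), so a sulfanyl link and a ring without chlorine also reach the limit, something that only the 3-chlorobenzyl of compound 2 had done before, though neither floor is shown to exceed the scatter. The full size of these steps stays unknown and the step between compound 2 and compound 4 cannot be read: the limit of > 50000 nM in this assay, at which 2 of the 4 values shown sit.

Going by these compounds, whether the sulfanyl link or the two methyl groups bear on this result remains open, as the exchange changes both at once. On these data alone, how an amine or a (3-chlorophenyl)sulfanyl group would read on this saturated chain carbon is also open.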